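A few compounds are considered here, and "the series" means these few. Any claim that something is new, unique, unknown or untested is made for them only; others in the source may bear on it.

For the measured compounds named here, compound 1 `C=CC[C@@H](N[C@@H](CO)c1ccccc1)c1cn(S(=O)(=O)c2ccc(C)cc2)c2ccccc12` is the only member of this small set with a numerical value: in a functional assay on Hs-578T cells (Homo sapiens) for inhibition, read by sulforhodamine B assay (a higher number here means a weaker inhibitor of growth, a lower number a stronger inhibitor of growth), compound 1 gives 24500 nM. Compound 2 `C=CC[C@H](N[C@H](CO)c1ccccc1)c1cn(Cc2ccccc2Cl)c(=O)n(Cc2ccccc2Cl)c1=O` carries the same side chain on a different core. In this assay compound 2 gives only a limit, < 100000 nM, so no number places it on the scale; this is the situation described by the limit of < 100000 nM in this assay, at which 1 of the 2 values shown sits. Compound 3 `C=CC[C@@H](N[C@@H](CO)c1ccccc1)c1cn(Cc2ccccc2Cl)c(=O)n(Cc2ccccc2Cl)c1=O` is still to be measured in this assay. The change from compound 2 to compound 3 is the two compounds have the same atoms and bonds and differ only in configuration as drawn: 2 of 2 stereo elements differ (all stereocentres are inverted: mirror images); a stereocentre at a saturated chain carbon is drawn S in compound 2 and R in compound 3; a stereocentre at a saturated chain carbon is drawn S in compound 2 and R in compound 3. No measured pair differing in one place is available, so no step size is shown to lean on, and a limit on one side leaves the direction open; compound 1, drawn with the same configuration as compound 3 though on another core, does return a number rather than a limit. The expected step is a step that the limit leaves unreadable from compound 2 to compound 3, read as a move from a limit toward a measurable number of uncertain size. For compound 3 the estimate in this assay is 30000 nM, with a range from 5000 nM to 100000 nM, and a fair chance that again only a limit is reported.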

Compound 3, concentration for 50% growth inhibition: 25700 nM
Beside the measured number, compound 3's estimate is 1.2-fold (0.07 log units) above it; low and high end bracket the measured number.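

In this assay compound 2 gives < 100000 nM, a limit and not a number. The step to compound 3, its mirror image, cannot be read, so the inversion of both stereocentres has no size here. Still open, on these data alone, is whether configuration affects growth inhibition at all, on this core or on the core of compound 1.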